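The compounds below may be only part of what the source reports. "The series", "measured", "known", "first", "only" and "open" are said of these compounds alone.

Measured compounds:
Compound 1 `COc1cccc(-c2csc(N/N=C3\CCC(C)C3)n2)c1` gives 231 nM in an assay on isolated protein for inhibition of Amine oxidase [flavin-containing] B (Homo sapiens), read by fluorescence; on this read-out lower numbers stand for stronger inhibition and higher numbers for weaker inhibition.
Compound 2 `COc1cccc(-c2csc(N/N=C(\C)c3cccnc3)n2)c1` gives 3.81 nM in this assay.
Compound 3 `COc1cccc(-c2csc(N/N=C/c3c[nH]c4ccccc34)n2)c1` gives 800 nM in this assay.

Among these three, compound 2 holds the lowest number in this assay; compound 1 stands well above it and compound 3 further still, and both of those gaps lie beyond the usual scatter. Compound 4 `COc1cccc(-c2csc(N/N=C(\C)c3cccs3)n2)c1` has not yet been measured in this assay. It differs from compound 2 in one place: thiophen-2-yl in place of pyridin-3-yl on a carbon with a double bond to nitrogen. Going by the values given here, no pair of the measured compounds differs in just one place, so there is no measured step to rest on, and the three measured compounds differ from one another in more than one part at once. The change swaps one aromatic ring bearing one hetero atom for another of a different ring size, while the saturated chain carbon on the carbon with a double bond to nitrogen and the rest of the molecule stay as they are. On that basis compound 4 is expected to remain near compound 2, with a small step of a 2.1-fold higher number from compound 2 to compound 4 (0.32 log units; beyond the scatter) toward a somewhat higher number that may not exceed the scatter. The estimate for compound 4 in this assay is 8 nM, with a range from 2 nM to 40 nM.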

Compound 4, half-maximal inhibitory concentration: 551 nM
Estimate against measurement, compound 4: 69-fold (1.84 log units) below, and the stated range ends below it.
By their numbers in this assay, from the lowest: compound 2; then compound 1; then compounds 4 and 3 (each within the scatter of the next).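

Placing thiophen-2-yl in place of pyridin-3-yl on a carbon with a double bond to nitrogen gives, in this assay, a 140-fold higher number from compound 2 to compound 4 (2.16 log units; beyond the scatter), the first single-place step in this set and a large one. It shows that this position is far from indifferent to which aromatic ring it carries: the saturated chain carbon and the rest of the molecule stay as they are, and both rings carry one hetero atom, no hydrogen-bond donors, one hydrogen-bond acceptor and no net charge, so these counts do not separate the two groups even though the numbers lie far apart. Nothing measured here explains the size of this step.

The compounds shown leave open whether the step follows the ring size, the identity of the hetero atom or the point of attachment, a question that phenyl, furan-2-yl, thiophen-3-yl or pyridin-2-yl at this place would help to divide. They also leave open whether a pyridin-3-yl ring carrying a further group, such as an amine or a methoxy group, would stay near compound 2.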